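The source may hold more compounds than are shown below. What is called first, only, known or untested is meant among the compounds shown, and "the series" means these compounds.

Measured so far:
compound 1, `Nc1nc(Nc2ccccc2)nc2[nH]c(=O)c(-c3ccccc3)cc12`, 13800 nM in an ADME assay on Huh-7 cells (Homo sapiens) for cytotoxicity, read by MTT assay, with a stated time of 4 h, at 37 degrees C; a lower number here means that less compound is tolerated, a higher number that more compound is tolerated
compound 2, `Cn1c(=O)c(-c2ccccc2)cc2c(N)nc(Nc3ccccc3)nc21`, 23500 nM in this assay
compound 3, `CCCOCCNc1nc(N)nc2c1cc(-c1ccc(F)cc1)c(=O)n2C`, 54300 nM in this assay

Compound 1 and compound 2 share a core and differ only by hydrogen in place of methyl on an aromatic nitrogen; this step gives a 1.7-fold lower number from compound 2 to compound 1 (0.23 log units; within the scatter). Compound 3 has the highest number of the three measured; how its core differs from that of compound 2 is not broken down here.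

Compound 4, `CCCOCCNc1nc(N)nc2[nH]c(=O)c(-c3ccc(F)cc3)cc12`, has not yet been measured in this assay. It differs from compound 3 by hydrogen in place of methyl on an aromatic nitrogen. This is the same kind of change as that from compound 2 to compound 1, though around the place the neighbouring group is a 4-fluorophenyl group rather than a phenyl group. Because the earlier step of a 1.7-fold lower number from compound 2 to compound 1 (0.23 log units; within the scatter) stayed within the scatter, the step to compound 4 is expected to be a 1.7-fold lower number from compound 3 to compound 4 (0.23 log units; within the scatter), and compound 4 is estimated at 32000 nM, between 15000 nM and 70000 nM.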

Compound 4, half-maximal cytotoxic concentration: 130000 nM
Compound 4: the middle estimate sits 4.1-fold (0.61 log units) below what was measured, outside the stated range (above it).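

Putting hydrogen in place of methyl on the aromatic nitrogen gives a 2.4-fold higher number from compound 3 to compound 4 (0.38 log units; beyond the scatter) in this assay. The same change therefore does not carry over with a fixed size or direction between these two cores, and the earlier step would not have been a safe guide to this one: the same change on two cores in this assay, a 1.7-fold lower number (0.23 log units; within the scatter) from compound 2 to compound 1 and a 2.4-fold higher number (0.38 log units; beyond the scatter) from compound 3 to compound 4, 4.1-fold (0.61 log units) apart, beyond the scatter of two such steps What sets the two steps apart is not shown, as the two pairs differ elsewhere in more than one way, including a 4-fluorophenyl group in place of a phenyl group.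

From the compounds shown here alone, it remains open how the change behaves when only one of those differences is present. Also open, going by these compounds, is what an ethyl group or a longer chain carrying an amine would do on that nitrogen.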